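A few compounds are considered here, and "the series" means these few. Any claim that something is new, unique, unknown or untested is made for them only; others in the source may bear on it.

The measured compounds: compound 1 `CCCCCCOc1ccc2c(=O)c(-c3ccc(O)cc3)coc2c1` gives 1500 nM in an assay (Cricetulus griseus) for inhibition of aldehyde dehydrogenase, mitochondrial (Homo sapiens); a higher number here means a weaker inhibitor, a lower number a stronger inhibitor. Compound 3 `O=C(O)COc1ccc2c(=O)c(-c3ccc(O)cc3)coc2c1` gives 1200 nM in this assay. Compound 2 `CCCCCCCCCCCCOc1ccc2c(=O)c(-c3ccc(O)cc3)coc2c1` gives only a limit in this assay, > 9000 nM. That figure is the limit of > 9000 nM in this assay, at which 1 of the 3 values shown sits.

From compound 1 to compound 2 the change is hexyl in place of hydrogen on a saturated chain carbon, six bonds along the chain from an oxygen on an aromatic ring, and the step is an at least 6.0-fold higher number from compound 1 to compound 2 (0.77 log units; beyond the scatter). The cores of compound 1 and compound 3 differ by carboxy in place of pentyl on a saturated chain carbon bound to an oxygen on an aromatic ring, and the step between them is a 1.3-fold lower number from compound 1 to compound 3 (0.10 log units; within the scatter). Compound 4 `CCCCCCC(Oc1ccc2c(=O)c(-c3ccc(O)cc3)coc2c1)C(=O)O` has not yet been measured in this assay. It differs from compound 3 by hexyl in place of hydrogen on a saturated chain carbon bound to a carbonyl carbon and an oxygen on an aromatic ring. The same group enters as between compound 1 and compound 2, but the place is not the same: there it is on a saturated chain carbon six bonds along the chain from an oxygen on an aromatic ring, here on a saturated chain carbon bound to a carbonyl carbon and an oxygen on an aromatic ring, so this is the same kind of change rather than the same one. The step from compound 3 to compound 4 is expected to be a 2.1-fold higher number from compound 3 to compound 4 (0.32 log units; beyond the scatter), smaller than the earlier one, because compound 1, which already carries a chain of about this length, gives 1500 nM. Compound 4 is therefore expected to give 2500 nM, most likely between 900 nM and 9000 nM.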

Compound 4, half-maximal inhibitory concentration: 2000 nM
For compound 4 the middle estimate is 1.3-fold (0.10 log units) above the measured one; measured number inside the range.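

In this assay, hexyl in place of hydrogen on a saturated chain carbon bound to a carbonyl carbon and an oxygen on an aromatic ring gives a 1.7-fold higher number from compound 3 to compound 4 (0.22 log units; within the scatter), so on the core of compound 3 this change leaves the number within the scatter. Set beside the earlier step, the change does not carry over from one core to the other with the same size: the same change on two cores in this assay, an at least 6.0-fold higher number (0.77 log units; beyond the scatter) from compound 1 to compound 2 and a 1.7-fold higher number (0.22 log units; within the scatter) from compound 3 to compound 4, at least 3.6-fold (0.55 log units) apart, beyond the scatter of two such steps. This does not show the true size of the earlier step, nor whether the different core or the different place of the hexyl lies behind the gap, and the value of compound 2 is a limit rather than a number: the limit of > 9000 nM in this assay, at which 1 of the 4 values shown sits.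

The compounds shown leave open whether a shorter chain or a longer chain on that saturated chain carbon would behave as hexyl does. They also leave open whether hexyl would give a similar step on a core carrying an ester or an amide in place of the carboxy group.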